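The source may report more compounds than this note shows. Statements on the series, on what has been measured and on what is new or still open speak of the compounds shown alone.

Measured so far:
compound 1 `CC(C)C(NC(=O)NO)C(=O)NC1CCCCC1` — > 100000 nM
compound 2 `CC(C)C(NC(=O)NO)C(=O)NC1CCCC1` — > 100000 nM
compound 3 `CC(C)C(NC(=O)n1nnc2ccccc21)C(=O)NC1CCCC1` — 96400 nM

In a functional assay on HeLa cells (Homo sapiens) for inhibition (on this read-out higher numbers stand for weaker inhibition and lower numbers for stronger inhibition), compound 1 gives > 100000 nM, which is a limit of the assay and not a number. Compound 2 likewise gives > 100000 nM, a limit. Among the compounds with values here, compound 3 gives 96400 nM, the only number among the three. The step that the two limits leave unreadable from compound 2 to compound 1 cannot be read because both ends sit at the limit of > 100000 nM in this assay, at which 2 of the 3 values shown sit. How the core of compound 2 differs from that of compound 3 is not broken down here.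

Compound 4 `CC(C)C(NC(=O)n1nnc2ccccc21)C(=O)NC1CCCCC1` is not yet measured in this assay. It differs from compound 3 by cyclohexyl in place of cyclopentyl on an amide-type nitrogen, the same change as cyclohexyl in place of cyclopentyl on an amide-type nitrogen between compound 2 and compound 1. Since that earlier step is unreadable, the step from compound 3 to compound 4 is expected to be small, a 1.0-fold higher number from compound 3 to compound 4 (0.02 log units; within the scatter). Compound 4 is expected to give about 100000 nM, estimated between 30000 nM and 300000 nM.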

Compound 4, half-maximal inhibitory concentration: 96400 nM
For compound 4 the middle estimate is 1.0-fold (0.02 log units) above the measured one; measured number inside the range.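

In this assay, cyclohexyl in place of cyclopentyl on an amide-type nitrogen gives no change at the digits printed from compound 3 to compound 4 (within the scatter). The same change on the core of compound 2, which leads to compound 1, cannot be read because both of its ends are limits of the assay and not numbers: the limit of > 100000 nM in this assay, at which 2 of the 4 values shown sit.

Within the data shown here, the single readable step therefore describes one core only, and it does not show whether the change behaves alike on the two cores. The compounds shown leave open how phenyl or cycloheptyl on that nitrogen would read on the core of compound 3. They also leave open whether any group there, such as an amine or a carboxylic acid, would separate from cyclopentyl and cyclohexyl in this assay.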